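This account rests on a few compounds, and the source may have more. Where it says the series, first, only, none or still open, it means among the compounds named here.

Measured so far in a functional assay on the whole organism with Mus musculus as the target, in the rotarod test; on this read-out higher numbers stand for an effect only at larger amounts of compound and lower numbers for an effect already at smaller amounts:
- compound 1 `CN(C(=O)CNC(=O)CN1CCCCC1)c1ccc(Cl)cc1C(=O)c1ccccc1Cl`: > 100 mg/kg
- compound 2 `CN(C(=O)CNC(=O)c1ccccc1)c1ccc(Cl)cc1C(=O)c1ccccc1Cl`: > 100 mg/kg
- compound 3 `CC(C)C(=O)NCC(=O)N(C)c1ccc(Cl)cc1C(=O)c1ccccc1Cl`: > 100 mg/kg

Each of these entries is a limit of the assay and not a number. Compound 3 stands at > 100 mg/kg, which is a limit. Among the compounds with values here, the whole series so far reads as the limit of > 100 mg/kg in this assay, at which 3 of the 3 values shown sit.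

Compound 4 `CCCC(=O)NCC(=O)N(C)c1ccc(Cl)cc1C(=O)c1ccccc1Cl` carries propyl in place of isopropyl on a carbonyl carbon. Within the data shown here, the steps that bear on this place are a step that the two limits leave unreadable from compound 2 to compound 3, a step that the two limits leave unreadable from compound 1 to compound 3 and a step that the two limits leave unreadable from compound 1 to compound 2. All three change the group on a carbonyl carbon, and none has a readable size. Among the measured compounds shown here, they offer no ground for a step of any size or direction in this assay, so nothing beyond the scatter is expected, and another limit is the most likely report. The expected step is a step that the limit leaves unreadable from compound 3 to compound 4. For compound 4 the estimated value is 150 mg/kg, with an expected range from 60 mg/kg to 400 mg/kg.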

Compound 4, dose for half-maximal effect: 55.2 mg/kg
Compound 4: the middle estimate sits 2.7-fold (0.43 log units) above what was measured; the whole stated range lies above it.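

The group on the carbonyl carbon is the first place in the series to give a readable value in this assay, while the rest of the series stays at a limit: the limit of > 100 mg/kg in this assay, at which 3 of the 4 values shown sit.
With the same atoms joined differently, propyl in place of isopropyl gives an at least 1.8-fold lower number from compound 3 to compound 4 (0.25 log units; that floor lies within the scatter). The comparisons with the other two groups read alike, with an at least 1.8-fold lower number from compound 2 to compound 4 (0.25 log units; that floor lies within the scatter) and an at least 1.8-fold lower number from compound 1 to compound 4 (0.25 log units; that floor lies within the scatter), so the series now holds a straight propyl chain with a measured value, though each of these steps is only a floor set by a limit.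

On these data alone, the true size of these steps stays open, and the steps among compound 1, compound 2 and compound 3 cannot be read. Also open, as far as these compounds go, is whether a longer chain such as butyl, or a terminal amine or carboxylic acid on the propyl chain, would shift the number further.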